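The compounds below may be only part of what the source reports. "The series", "measured", "known", "first", "only" and "open" are said of these compounds alone.

Of the compounds shown here, three sharing one core have been measured so far. Compound 1 `Ic1ccc(Cn2cc(CCCOc3cccc4cccnc34)nn2)cc1` gives 24.7 ug/mL in a functional assay on PC-3 cells (Homo sapiens) for inhibition, read by sulforhodamine B assay, with a stated time of 48 h; a higher number here means a weaker inhibitor of growth, a lower number a stronger inhibitor of growth. Compound 2 `Fc1ccc(Cn2cc(CCCOc3cccc4cccnc34)nn2)cc1F` gives 6.6 ug/mL in this assay, and compound 3 `Clc1cc(Cl)c(Cn2cc(CCCOc3cccc4cccnc34)nn2)c(Cl)c1` gives 2.8 ug/mL. Among these three numbers compound 3 has the lowest; the step of an 8.8-fold lower number from compound 1 to compound 3 (0.95 log units; beyond the scatter) is the largest seen, while a 2.4-fold lower number from compound 2 to compound 3 (0.37 log units; beyond the scatter) and a 3.7-fold lower number from compound 1 to compound 2 (0.57 log units; beyond the scatter) are smaller but still beyond the scatter. Compound 4 `c1ccc(Cn2cc(CCCOc3cccc4cccnc34)nn2)cc1` differs from compound 3 in one place: phenyl in place of 2,4,6-trichlorophenyl on a saturated chain carbon bound to an aromatic nitrogen. Going by the values given here, no measured step matches this change exactly, but all three bear on it, since each alters only the halogen pattern of the same ring at the same place, and the ring carrying no halogen at all has not yet been measured. Each measured step moved the number by a modest amount, and the ring of compound 4 sits further from that of compound 3 than compound 2 or compound 1 does. A step upward beyond the scatter is therefore expected for compound 4, estimated at a 5.0-fold higher number from compound 3 to compound 4 (0.70 log units; beyond the scatter) in this assay. Compound 4 is expected to give about 14 ug/mL, likely between 5 ug/mL and 40 ug/mL.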

Compound 4, concentration for 50% growth inhibition: 16.8 ug/mL
Compound 4: the middle estimate sits 1.2-fold (0.08 log units) below what was measured; the measured number falls inside the stated range.
By their numbers in this assay, from the lowest: compound 3; then compound 2; then compounds 4 and 1 (each within the scatter of the next).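

With the ring free of halogen now in hand, this assay shows that halogens at this place do not all act alike: the 2,4,6-trichlorophenyl and 3,4-difluorophenyl groups both give lower numbers than phenyl, as a 6.0-fold higher number from compound 3 to compound 4 (0.78 log units; beyond the scatter) and a 2.5-fold higher number from compound 2 to compound 4 (0.41 log units; beyond the scatter) show. The 4-iodophenyl group goes against this pattern, since a 1.5-fold lower number from compound 1 to compound 4 (0.17 log units; within the scatter) means that hydrogen in place of iodo on this aromatic carbon makes no readable difference. No measurement at hand accounts for this difference among the halogen patterns.

The compounds shown leave open how a single chlorine, a methoxy group, an amine or a carboxylic acid on this ring would behave. They also cannot separate the kind of halogen from its pattern, since the 2,4,6-trichlorophenyl and 3,4-difluorophenyl groups differ in both.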